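The source may hold more compounds than are shown below. What is called first, only, known or untested is meant among the compounds shown, and "the series" means these compounds.

Compound 1 `Cc1cc2nn(-c3ccccc3)c(N)c2c(=O)[nH]1` and compound 2 `CC(C)(C)c1cc2nn(-c3ccccc3)c(N)c2c(=O)[nH]1` share one core. In an assay on isolated protein for inhibition of ribosomal protein S6 kinase alpha-5 (Homo sapiens), read by mobility shift assay, tested at 30 uM (on this read-out lower numbers stand for less inhibition and higher numbers for more inhibition at the one concentration tested (going by the name of the read-out)), compound 1 gives 4% and compound 2 gives -1%. The step of a number 5 percentage points lower from compound 1 to compound 2 (within the scatter), tert-butyl in place of methyl on an aromatic carbon, stays within the scatter. Compound 2 stands lowest of the two numbers, with compound 1 within the scatter of it. Compound 3 `Nc1c2c(=O)[nH]c(-c3ccccc3)cc2nn1-c1ccccc1` differs from compound 2 by phenyl in place of tert-butyl on an aromatic carbon. Going by the values given here, no measured step covers phenyl at this position; the one step at this carbon, a number 5 percentage points lower from compound 1 to compound 2 (within the scatter), is within the scatter, so no step beyond the scatter is expected. Compound 3 is expected near 2%, in a range from -10% to 15%, an expected step of a number 3 percentage points higher from compound 2 to compound 3 (within the scatter).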

Compound 3, a percentage reported as inhibition, at one concentration (the size of the read-out at that concentration, not a potency): 13%
Compound 3: the middle estimate sits 11 percentage points below what was measured; the measured number falls inside the stated range.
By their numbers in this assay, from the lowest: compounds 2, 1 and 3 (each within the scatter of the next, the first and the last beyond it).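

The step of a number 14 percentage points higher from compound 2 to compound 3 (beyond the scatter) for phenyl in place of tert-butyl is the only one at this aromatic carbon that leaves the scatter. The step of a number 9 percentage points higher from compound 1 to compound 3 (within the scatter) for phenyl in place of methyl does not, so phenyl separates from tert-butyl but not from methyl. Nothing available explains the step.

Still open, on these data alone, is whether an amine, a carboxylic acid or a longer alkyl chain on this carbon would give a larger number. Also open, as far as these compounds go, is how substituents on the entering phenyl would read.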